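This account rests on a few compounds, and the source may have more. Where it says the series, first, only, none or still open, it means among the compounds named here.

In a functional assay on SK-OV-3 cells (Homo sapiens) for antiproliferative activity, read by MTT assay, with a stated time of 72 h (a lower number here means a stronger inhibitor, a higher number a weaker inhibitor), compound 1 (`COc1cc(OC)cc(-c2cccc(NC(=O)CCc3cccc4c3B(O)OC4)c2)c1`) gives 44 nM and compound 2 (`COc1cc(OC)cc(-c2cccc(NC(=O)CCc3ccc4c(c3)B(O)OC4)c2)c1`) gives 29000 nM, while compound 3 (`COc1cccc(-c2cccc(NC(=O)CCc3cccc4c3COB4O)c2)c1`) gives 78000 nM as the highest of the three numbers, which makes it the weakest inhibitor so far. Compound 2 stands nearest to it and compound 1 furthest.

Compound 4 (`COc1cc(OC)cc(-c2cccc(NC(=O)CCc3cccc4c3COB4O)c2)c1`) keeps the core of compound 3 and changes one place (methoxy in place of hydrogen on an aromatic carbon), with methoxy in place of hydrogen on an aromatic carbon. In this way 3-methoxyphenyl becomes 3,5-dimethoxyphenyl, the group also carried by compound 1 and compound 2.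

Going by the values given here, no measured pair shows this change alone. Among the compounds with values here, the only measured step (a 660-fold higher number from compound 1 to compound 2 (2.82 log units; beyond the scatter)) keeps 3,5-dimethoxyphenyl and alters the group on the chain, and it is large. Carrying 3,5-dimethoxyphenyl therefore does not by itself give a low number, as compound 2 has it and still stands at 29000 nM in this series. The low number of compound 1 cannot simply be carried over either, since compound 4 has the core of compound 3 instead.

A moderate move toward a lower number is expected, with wide uncertainty, and the estimated change (a 26-fold lower number from compound 3 to compound 4 (1.41 log units; beyond the scatter)) reflects this. For compound 4 the estimated value is 3000 nM with 100 nM to 60000 nM as the expected range.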

Compound 4, half-maximal inhibitory concentration: 88000 nM
Compound 4: middle estimate off by 29-fold (1.47 log units), on the low side; measured number outside the range, above it.
By their numbers in this assay, from the lowest: compound 1; then compound 2; then compounds 3 and 4 (each within the scatter of the next).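

In this assay, the extra methoxy on the core of compound 3 leaves the number in place, a 1.1-fold higher number from compound 3 to compound 4 (0.05 log units; within the scatter), so on this core the change from 3-methoxyphenyl to 3,5-dimethoxyphenyl shows no measurable effect at this aromatic carbon. With 3,5-dimethoxyphenyl now common to compound 1, compound 2 and compound 4, only the group on the chain differs: there is a 2000-fold higher number from compound 1 to compound 4 (3.30 log units; beyond the scatter), which is large, and a 3.0-fold higher number from compound 2 to compound 4 (0.48 log units; beyond the scatter), which is modest, so the low number of compound 1 goes with its own form of that group and not with 3,5-dimethoxyphenyl alone. No independent measurement is available to explain these differences.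

Going by these compounds, this one-place change has been read only on the core of compound 3, so whether it would also leave the number unchanged on the core of compound 1, where the number is far lower, remains open. Also open, on these data alone, is how an amine or a carboxylic acid would read in place of methoxy on this aromatic carbon, and whether a longer chain would alter the large gap seen with compound 1.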